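A Phenyl Swap at the Edge of the Assay Limit

This account rests on a few compounds, and the source may have more. Where it says the series, first, only, none or still open, it means among the compounds named here.

Compound 1 `COc1ccc(Nc2ncc(C(F)(F)F)c(N3Cc4cccc(N(C)S(C)(=O)=O)c4C3)n2)cc1C(F)(F)F`: > 30000 nM
Compound 2 `Cc1ccc(Nc2ncc(C(F)(F)F)c(N3Cc4cccc(N(C)S(C)(=O)=O)c4C3)n2)c(Cl)c1`: > 30000 nM
Compound 3 `Cc1ccc(Nc2ncc(C(F)(F)F)c(N3Cc4cccc(N(C)S(C)(=O)=O)c4C3)n2)c(C)c1`: 19100 nM

In a functional assay on HepG2 cells (Homo sapiens) for antiproliferative activity, read by spectrophotometry, with a stated time of 2 days (on this read-out higher numbers stand for weaker inhibition of growth and lower numbers for stronger inhibition of growth), compound 1 gives only a limit, > 30000 nM. Compound 2 likewise gives a limit rather than a number, > 30000 nM. Compound 3 alone gives a measured number, 19100 nM. The steps of an at least 1.5-fold lower number from compound 2 to compound 3 (0.19 log units; that floor lies within the scatter) and an at least 1.5-fold lower number from compound 1 to compound 3 (0.19 log units; that floor lies within the scatter) are therefore floors only, and a step that the two limits leave unreadable from compound 1 to compound 2. Two of the three values sit at the limit of > 30000 nM in this assay, at which 2 of the 3 values shown sit.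

Compound 4 `CN(c1cccc2c1CN(c1nc(Nc3ccc(Cl)c(C(F)(F)F)c3)ncc1C(F)(F)F)C2)S(C)(=O)=O` differs from compound 2 by 4-chloro-3-(trifluoromethyl)phenyl in place of 2-chloro-4-methylphenyl on a nitrogen on an aromatic ring. Within the data shown here, no measured step leads into a phenyl carrying a trifluoromethyl and a chloro together, so the nearest point of comparison is compound 1, which also carries a trifluoromethyl on that phenyl and gives a limit of > 30000 nM. For compound 4 the expected step is a step that the limit leaves unreadable from compound 2 to compound 4, none beyond the scatter, with a limit the most likely outcome. Compound 4 is estimated at 35000 nM, in the range 15000 nM to 80000 nM.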

Compound 4, concentration for 50% growth inhibition: 16000 nM
Compound 4: middle estimate off by 2.2-fold (0.34 log units), on the high side; the measured number falls inside the stated range.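

In this assay compound 4 gives a measured number, 16000 nM, so a phenyl carrying a trifluoromethyl group can yield a readable value on this nitrogen. The comparison between the two measured compounds shows a 1.2-fold lower number from compound 3 to compound 4 (0.08 log units; within the scatter), so 4-chloro-3-(trifluoromethyl)phenyl and 2,4-dimethylphenyl cannot be separated here. The other two comparisons, an at least 1.8-fold lower number from compound 1 to compound 4 (0.27 log units; that floor lies within the scatter) and an at least 1.8-fold lower number from compound 2 to compound 4 (0.27 log units; that floor lies within the scatter), give only floors, and each starts from a compound held at an assay limit: the limit of > 30000 nM in this assay, at which 2 of the 4 values shown sit.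

The compounds shown leave open how far compound 1 and compound 2 truly lie from compound 4, and whether any change to this phenyl moves the number beyond the scatter. They also leave open what an amine or a carboxylic acid in place of the chloro on this phenyl would give.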